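From a Pentyl Chain to a Pyridine Ring

The source may hold more compounds than are shown below. What is called first, only, known or untested is meant among the compounds shown, and "the series" means these compounds.

Three compounds share one core and differ only in the group attached to an aromatic carbon of its five-membered ring. Compound 1 `Nc1nc(N2CCN(C(=O)COc3ccc(Cl)cc3)CC2)c2nc(CCCc3ccc(F)cc3)sc2n1` carries a chain that ends in 4-fluorophenyl; in a functional assay on cells (Lymphocyte, Homo sapiens) (a lower number here means a stronger inhibitor, a higher number a weaker inhibitor), compound 1 gives 960 nM. Compound 2 `Nc1nc(N2CCN(C(=O)COc3ccc(Cl)cc3)CC2)c2nc(CCCCc3ccc(F)cc3)sc2n1` has a chain one carbon longer, and compound 2 gives 920 nM. Compound 3 `CCCCCc1nc2c(N3CCN(C(=O)COc4ccc(Cl)cc4)CC3)nc(N)nc2s1` carries a plain pentyl chain, and compound 3 gives 690 nM. Compound 3 shows the lowest of the three numbers, yet the steps leading to it, a 1.4-fold lower number from compound 1 to compound 3 (0.14 log units; within the scatter) and a 1.3-fold lower number from compound 2 to compound 3 (0.12 log units; within the scatter), are within the scatter, as is a 1.0-fold lower number from compound 1 to compound 2 (0.02 log units; within the scatter); the three compounds cannot be told apart on these figures.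

Compound 4 `Nc1nc(N2CCN(C(=O)COc3ccc(Cl)cc3)CC2)c2nc(-c3cccnc3)sc2n1` has not been measured. Its change from compound 3 is pyridin-3-yl in place of pentyl on an aromatic carbon. Within the data shown here, no measured step replaces a chain with an aromatic ring on this aromatic carbon: the three steps seen alter only a chain, and none moved the number beyond the scatter. There is thus no basis for expecting a shift in either direction, and the step of a 1.4-fold higher number from compound 3 to compound 4 (0.16 log units; within the scatter) is estimated accordingly, with wide uncertainty. Compound 4 is expected to give 1000 nM, within the range 300 nM to 3500 nM.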

Compound 4, half-maximal inhibitory concentration: 50 nM
For compound 4 the middle estimate is 20-fold (1.30 log units) above the measured one, and the stated range ends above it.
By their numbers in this assay, from the lowest: compound 4; then compounds 3, 2 and 1 (each within the scatter of the next).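

In this assay this aromatic carbon proves sensitive to the group it carries, something the three chains gave no sign of: pyridin-3-yl in place of pentyl gives a 14-fold lower number from compound 3 to compound 4 (1.14 log units; beyond the scatter) and the same ring in place of the two chains ending in 4-fluorophenyl gives an 18-fold lower number from compound 2 to compound 4 (1.26 log units; beyond the scatter) and a 19-fold lower number from compound 1 to compound 4 (1.28 log units; beyond the scatter) in turn. Changing the chain's length or its end left the number within the scatter, while putting a six-membered aromatic ring directly on this carbon moves it well beyond the scatter, so the flat picture from the chains does not hold for every kind of group here. Nothing at hand explains why this change matters so much.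

Left open is whether plain phenyl would do the same, which would show if the ring nitrogen matters at all, and whether pyridin-2-yl or pyridin-4-yl would match pyridin-3-yl. Also open, on these data alone, is whether the ring must sit directly on this carbon, a question that a pyridin-3-ylmethyl group would address.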